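Series notes on the step to compound 4

The compounds below may be only part of what the source reports. "The series", "measured", "known", "first", "only" and "open" are said of these compounds alone.

In an ADME assay on microsomes from liver (Rattus norvegicus) for metabolic stability (a lower number here means slower removal, a higher number faster removal of the compound), compound 1 (`CC(C)Oc1cc(Oc2ccc(S(C)(=O)=O)cc2)cc(-c2cccc(=O)[nH]2)c1`) gives 349 mL/min/kg, compound 2 (`CC(C)Oc1cc(Oc2ccc(S(C)(=O)=O)cc2)cc(-c2cncc(=O)[nH]2)c1`) gives 61 mL/min/kg and compound 3 (`Cc1cc(=O)[nH]c(-c2cc(Oc3ccc(S(C)(=O)=O)cc3)cc(OC(C)C)c2)n1`) gives 96 mL/min/kg. Compound 3 thus stands within the scatter of compound 2 and clearly under compound 1. Compound 4 (`CCc1cnc(-c2cc(Oc3ccc(S(C)(=O)=O)cc3)cc(OC(C)C)c2)[nH]c1=O`) differs from compound 3 as follows: a group of 9 heavy atoms (6 carbon, 2 nitrogen, 1 oxygen; one six-membered aromatic ring with 2 hetero atoms) in place of a group of 8 heavy atoms (5 carbon, 2 nitrogen, 1 oxygen; one six-membered aromatic ring with 2 hetero atoms), on an aromatic carbon. Among the measured compounds shown here, the closest precedent is a 1.6-fold higher number from compound 2 to compound 3 (0.20 log units; within the scatter), which also swaps one group with two ring hetero atoms for another. The larger steps, a 5.7-fold lower number from compound 1 to compound 2 (0.76 log units; beyond the scatter) and a 3.6-fold lower number from compound 1 to compound 3 (0.56 log units; beyond the scatter), both start from the group with one ring hetero atom, which is not what changes here. A small upward step, within the scatter, is therefore expected in this assay. The expected step is a 1.3-fold higher number from compound 3 to compound 4 (0.10 log units; within the scatter). For compound 4 the estimated value is 120 mL/min/kg, with an expected range of 55 mL/min/kg to 260 mL/min/kg.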

Compound 4, clearance: 171 mL/min/kg
Beside the measured number, compound 4's estimate is 1.4-fold (0.15 log units) below it; measured number inside the range.
By their numbers in this assay, from the lowest: compounds 2, 3 and 4 (each within the scatter of the next, the first and the last beyond it); then compound 1.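

With one more carbon in the group on this aromatic carbon, this assay separates compound 4 from compound 3 by no more than the scatter (a 1.8-fold higher number from compound 3 to compound 4 (0.25 log units; within the scatter)). Against the group of compound 2, however, the number does rise (a 2.8-fold higher number from compound 2 to compound 4 (0.45 log units; beyond the scatter)). Compound 4 also keeps only a small part of the drop seen with the other groups that have two ring hetero atoms (a 2.0-fold lower number from compound 1 to compound 4 (0.31 log units; beyond the scatter)), although that step remains beyond the scatter. As far as these compounds go, whether an amine, a carboxylic acid or a longer chain on this ring would bring the number nearer that of compound 2 stays open. Nothing available accounts for these steps.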